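The source may hold more compounds than are shown below. What is called first, only, known or untested is meant among the compounds shown, and "the series" means these compounds.

Working notes on the series. In an ADME assay on NIH3T3 cells (Mus musculus) for cytotoxicity, read by MTT assay, with a stated time of 24 h (a higher number here means a weaker inhibitor, a lower number a stronger inhibitor), compound 1 `O=C(CN1CCN(c2ccc(Cl)cc2)CC1)N1CCN(c2nnc(-c3ccccc3)c(-c3ccccc3)n2)CC1` gives 113000 nM. Compound 2 `Cc1ccc(-c2nnc(N3CCN(C(=O)CN4CCN(c5cccc(Cl)c5)CC4)CC3)nc2-c2ccc(C)cc2)cc1` gives 859000 nM in this assay. Compound 3 `COc1ccc(-c2nnc(N3CCN(C(=O)CN4CCN(c5ccccc5OC)CC4)CC3)nc2-c2ccc(OC)cc2)cc1` stands at the limit of > 821000 nM in this assay, at which 1 of the 3 values shown sits. For compound 3 the reading > 821000 nM in this assay is a limit of the assay, not a number.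

Compound 4 `COc1ccc(-c2nnc(N3CCN(C(=O)CN4CCN(c5cccc(Cl)c5)CC4)CC3)nc2-c2ccc(OC)cc2)cc1` differs from compound 3 by 3-chlorophenyl in place of 2-methoxyphenyl on an amine nitrogen in a ring. Within the data shown here, no step between measured compounds differing in one place is available, so the size of this step is open. Compound 2 also carries 3-chlorophenyl on that amine nitrogen and gave 859000 nM, which leaves the expected step from compound 3 to compound 4 at an at least 1.1-fold lower number from compound 3 to compound 4 (0.06 log units; that floor lies within the scatter), not clearly beyond the scatter. Compound 4 is estimated at 700000 nM, within 250000 nM to 2000000 nM, with a real chance that only a limit is reported.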

Compound 4, half-maximal inhibitory concentration: > 814000 nM
Compound 4: no number, only a limit (the forecaster's own chance of this, stated with the estimate: 45%); middle value at least 1.1-fold (0.06 log units) away from the limit.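

In this assay compound 4 gives > 814000 nM as a limit of the assay. Among these compounds, compound 3 gives > 821000 nM as a limit too, and no step to compound 4 can be read. Left open is what size of step, if any, 3-chlorophenyl in place of 2-methoxyphenyl produces.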